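The source may report more compounds than this note shows. Statements on the series, on what has been measured and on what is new or still open speak of the compounds shown alone.

Measured so far, in a functional assay on HeLa cells (Homo sapiens) for antiproliferative activity, with a stated time of 24 h; a lower number here means a stronger inhibitor, a higher number a weaker inhibitor:

compound 1 `Cc1ccccc1CN1CCc2c(sc(NC(=O)c3ccccc3Cl)c2C(N)=O)C1`: > 50000 nM, which is a limit of this assay and not a number
compound 2 `NC(=O)c1c(NC(=O)c2ccccc2Cl)sc2c1CCN(Cc1cc(Cl)cc(Cl)c1)C2`: 19600 nM

Among the compounds with values here, compound 2 holds the only finite number in this assay; the other value shown is a limit, (the limit of > 50000 nM in this assay, at which 1 of the 2 values shown sits). Within the data shown here, the step of an at least 2.5-fold lower number from compound 1 to compound 2 (0.40 log units; beyond the scatter) is the sole measured comparison and rests on one side on that limit.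

Compound 3 `NC(=O)c1c(NC(=O)c2ccccc2Cl)sc2c1CCN(C(=S)Nc1ccccc1I)C2` differs from compound 2 by a group of 10 heavy atoms (7 carbon, 1 nitrogen, 1 sulfur, 1 iodine; one six-membered aromatic ring of carbon only) in place of a group of 9 heavy atoms (7 carbon, 2 chlorine; one six-membered aromatic ring of carbon only), on an amine nitrogen in a ring. Among the measured compounds shown here, no measured step covers a change of this kind: the one step known, an at least 2.5-fold lower number from compound 1 to compound 2 (0.40 log units; beyond the scatter), swaps one benzyl group for another on the same nitrogen and cannot be read as a guide to a thiourea in that position. The series therefore gives no ground for a directed expectation, and the weak potency of compound 2 at 19600 nM leaves room for a result that is weaker still.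

Compound 3 is estimated to lie near compound 2, with the expected step of a 1.0-fold higher number from compound 2 to compound 3 (0.01 log units; within the scatter) being no change beyond the scatter, at 20000 nM (range 5000 nM to 60000 nM), with a fair chance that only a limit is reported.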

Compound 3, half-maximal inhibitory concentration: 29000 nM
For compound 3 the middle estimate is 1.5-fold (0.16 log units) below the measured one; measured number inside the range.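

In this assay, the thiourea group of compound 3 in place of the 3,5-dichlorobenzyl group on an amine nitrogen in a ring gives a 1.5-fold higher number from compound 2 to compound 3 (0.17 log units; within the scatter) and so no change that can be told from the scatter, although the entering group brings 1 hydrogen-bond donor and 1 hydrogen-bond acceptor. Within the data shown here, the earlier step only exchanged one benzyl group for another on this nitrogen, so this is the first measured sign that a group of another kind can sit here with the number remaining within the scatter of compound 2, at this weak level of this assay. The step of an at least 1.7-fold lower number from compound 1 to compound 3 (0.23 log units; that floor lies within the scatter) cannot be read as a real difference, since compound 1 carries a limit and not a number: the limit of > 50000 nM in this assay, at which 1 of the 3 values shown sits.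

Sulfur, iodine and the thiourea link all enter together, so the compounds shown do not separate them, and a urea or a thiourea with an unsubstituted phenyl would be needed to do so. Also open, on these data alone, is whether any group on this nitrogen, such as acetyl or a longer chain, or a carboxylic acid in place of the carboxamide of the shared core, moves the number clearly away from this level.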